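Acid Gives Way to an Unsaturated Ester

A few compounds are considered here, and "the series" means these few. Any claim that something is new, unique, unknown or untested is made for them only; others in the source may bear on it.

Compound 1 `O=C(O)CCc1ccncc1-c1ccc2ccccc2c1` gives 101% in an assay on a protein complex for inhibition of CDK8/Cyclin C (Homo sapiens), with a stated time of 1 h, tested at 10 uM (a higher number here means more inhibition at the concentration tested (going by the name of the read-out), a lower number less inhibition), the highest of the three numbers in hand, though its nearest neighbour lies within the scatter. That neighbour is compound 2 `O=C(CCc1ccncc1-c1ccc2ccccc2c1)N1CCOCC1`, which gives 100%; the step of a number 1 percentage points lower from compound 1 to compound 2 (within the scatter) shows that morpholin-4-yl in place of hydroxy on the carbonyl carbon leaves the read-out within the scatter. Furthest away stands compound 3 `CN1CCN(c2ccc(Nc3cnccc3/C=C/C(N)=O)cc2)CC1`, which gives 75%, beyond the scatter below compound 1. Compound 4 `CCOC(=O)/C=C/c1ccncc1-c1ccc2ccccc2c1` carries a different chain: 2-(ethoxycarbonyl)ethenyl in place of 2-carboxyethyl on an aromatic carbon. Among the measured compounds shown here, only one measured step bears on this change, the step from compound 1 to compound 2, and it was within the scatter; no measured pair exchanges the carboxylic acid for an ester or adds a double bond outside aromatic rings. Compound 1 and compound 2 both give high numbers whether the chain ends in hydroxy or in morpholin-4-yl, so compound 4 is expected to stay near the top, with an expected step of a number 6 percentage points lower from compound 1 to compound 4 (within the scatter) inside the scatter. The estimate for compound 4 is 95%, between 80% and 105%.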

Compound 4, a percentage reported as inhibition, at one concentration (the size of the read-out at that concentration, not a potency): 102%
For compound 4 the middle estimate is 7 percentage points below the measured one, and the stated range covers the measured number.
By their numbers in this assay, from the lowest: compound 3; then compounds 2, 1 and 4 (each within the scatter of the next).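

In this assay, the whole chain on the aromatic carbon opposite the ring nitrogen can be exchanged, not only the end of it, as the step of a number 1 percentage points higher from compound 1 to compound 4 (within the scatter) shows. The earlier step touched only the group on the carbonyl carbon, whereas here the entering chain has 7 heavy atoms in place of 5, 2 double bonds outside aromatic rings in place of 1, and 0 hydrogen-bond donors in place of 1, and the read-out stays within the scatter. Nothing measured here explains why the read-out holds through this change.

As far as these compounds go, whether a chain ending in an amine or a nitrile, or a longer chain, would hold the read-out at this position remains open. From the compounds shown here alone, each number is also a single-concentration read-out, so how compound 1 and compound 4 compare in potency remains open as well.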